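The compounds below may be only part of what the source reports. "The series", "measured", "known", "first", "only" and "open" are said of these compounds alone.

Measured in a functional assay on A549 cells (Homo sapiens) for inhibition, read by MTT assay, with a stated time of 72 h; a higher number here means a weaker inhibitor, a lower number a stronger inhibitor:
Compound 1 `COc1cc2c(Oc3ccc(NC(=O)c4nn(-c5ccccc5C)cc(C)c4=O)cc3)ccnc2cc1OCC(=O)NO`: 5980 nM
Compound 2 `COc1cc2c(Oc3ccc(NC(=O)c4nn(-c5ccccc5C)ccc4=O)cc3F)ccnc2cc1OCCCC(=O)NO`: 5740 nM
Compound 3 `COc1cc2c(Oc3ccc(NC(=O)c4nn(-c5ccccc5C(F)(F)F)ccc4=O)cc3)ccnc2cc1OCC(=O)NO`: > 20000 nM

In this assay compound 2 gives 5740 nM, and this lies within the scatter of the number for compound 1. Compound 3 is recorded only as a limit, > 20000 nM, so just two true numbers are available for comparison.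

Compound 4 `COc1cc2c(Oc3ccc(NC(=O)c4nn(-c5ccccc5C)cc(C)c4=O)cc3F)ccnc2cc1OCCCC(=O)NO` has not yet been measured. It departs from compound 2 through methyl in place of hydrogen on an aromatic carbon, on a six-membered aromatic ring with 2 nitrogen: methyl in place of hydrogen on an aromatic carbon. Going by the values given here, no measured pair isolates this change. The same methyl is present in compound 1, which gives 5980 nM, although that compound also differs from compound 2 elsewhere. On that basis, no step beyond the scatter is expected in this assay, and neither direction is favoured. The estimated step is a 1.1-fold lower number from compound 2 to compound 4 (0.06 log units; within the scatter). For compound 4 the expected value is 5000 nM, with an estimated range of 1800 nM to 14000 nM.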

Compound 4, half-maximal inhibitory concentration: 2090 nM
Estimate against measurement, compound 4: 2.4-fold (0.38 log units) above; measured number inside the range.
By their numbers in this assay, from the lowest: compound 4; then compounds 2 and 1 (each within the scatter of the next). At a limit, above all of these: compound 3.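

In this assay the methyl on an aromatic carbon of the six-membered aromatic ring with 2 nitrogen, opposite the ring nitrogen, now has a step of its own: a 2.7-fold lower number from compound 2 to compound 4 (0.44 log units; beyond the scatter). This is the first measured pair that isolates the change and the only step shown that lies beyond the scatter; compound 1 carries the same methyl but also differs from compound 2 elsewhere, so it could not show this. Nothing measured here bears on why the methyl has this effect.

From the compounds shown here alone, whether the same methyl gives a similar step with a different chain or a different group on the remaining rings stays open. The compounds shown also leave open what an ethyl, a methoxy or a chlorine at this carbon would give.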